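A few compounds are considered here, and "the series" means these few. Any claim that something is new, unique, unknown or untested is made for them only; others in the source may bear on it.

In a functional assay on HCT-116 cells (Homo sapiens) for inhibition (on this read-out higher numbers stand for weaker inhibition and lower numbers for stronger inhibition), three compounds sharing one core have been examined so far, and compound 1 (`CCNC(=O)c1noc(-c2cc(C(C)C)c(O)cc2O)c1-c1cc(COCC(=O)O)no1`) stands as "not determined" (no result reported) and so offers no comparison. Compound 2 (`C=CNCc1cc(-c2c(C(=O)NCC)noc2-c2cc(C(C)C)c(O)cc2O)on1`) gives 121 nM in this assay and compound 3 (`CCNC(=O)c1noc(-c2cc(C(C)C)c(O)cc2O)c1-c1cc(CNC(C)=O)no1`) gives 167 nM on the same read-out. Acetyl in place of vinyl on an amine nitrogen separates these two (a 1.4-fold higher number from compound 2 to compound 3 (0.14 log units; within the scatter)), so compound 3 stands level with compound 2, the only other number available.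

Compound 4 (`CCNC(=O)c1noc(-c2cc(C(C)C)c(O)cc2O)c1-c1cc(CN(C)C)no1`) has not yet been measured. It departs from compound 3 in one place, with dimethylamino in place of acetamido on a saturated chain carbon bound to an aromatic carbon.

Within the data shown here, only one measured step bears on this change. Going from compound 2 to compound 3 also altered what sits on an amine nitrogen, and that step stayed within the scatter (a 1.4-fold higher number from compound 2 to compound 3 (0.14 log units; within the scatter)). Among the measured compounds shown here, this is thin evidence, and no measured compound carries dimethylamino, so the range has to stay wide. The expected change is no more than scatter, in neither direction (a 1.0-fold lower number from compound 3 to compound 4 (0.02 log units; within the scatter)). For compound 4 the estimated value is about 160 nM (expected range 55 nM to 480 nM).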

Compound 4, half-maximal inhibitory concentration: 92 nM
The estimate for compound 4 lay 1.7-fold (0.24 log units) above the measured number; measured number inside the range.
By their numbers in this assay, from the lowest: compounds 4, 2 and 3 (each within the scatter of the next).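

In this assay, the new result adds a second kind of change on the saturated chain carbon bound to an aromatic carbon: dimethylamino in place of acetamido gives a 1.8-fold lower number from compound 3 to compound 4 (0.26 log units; within the scatter) and does not move the number beyond the scatter, and dimethylamino in place of vinylamino gives a 1.3-fold lower number from compound 2 to compound 4 (0.12 log units; within the scatter) with the same outcome. Among these compounds, earlier, the only comparison at this place was between two groups that both kept a hydrogen on the amine nitrogen side of the structure as drawn, whereas dimethylamino counts no hydrogen-bond donor against one for acetamido, and it also removes the carbonyl, so at this position neither that donor nor that double bond is needed to keep the read-out where compound 3 stands. No other measurement is available that could explain why these three groups read alike.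

Going by these compounds, whether this tolerance extends to a primary amine, to a longer chain such as diethylamino, or to a carboxylic acid with a measured number remains open. All three numbers also come from one cell assay, so how far the pattern holds beyond these compounds cannot be said.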